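Propyl for methyl on the core of compound 2

The compounds below may be only part of what the source reports. "The series", "measured", "known", "first", "only" and "open" are said of these compounds alone.

Three hydroxamic acids with a shared core have been measured in an assay on cells for inhibition of protein deacetylase HDAC6 (Homo sapiens), read by fluorescence, with stated times of 15 min and 60 min; on this read-out lower numbers stand for stronger inhibition and higher numbers for weaker inhibition. Compound 1 `Cc1cc(-c2ccc(F)cc2)nn1Cc1ccc(C(=O)NO)cc1` gives 8 nM. Compound 2 `Cc1cc(-c2ccc(F)cc2)n(Cc2ccc(C(=O)NO)cc2)n1` gives 20 nM, and compound 3 `Cc1ccc(-c2cc(C)nn2Cc2ccc(C(=O)NO)cc2)cc1` gives 29 nM. Compound 2 stands second highest of the three: its nearest neighbour is compound 3, and the step from compound 2 to compound 3 is a 1.5-fold higher number from compound 2 to compound 3 (0.16 log units; within the scatter); its furthest is compound 1, whose number is lower by an amount that lies beyond the scatter.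

The next compound, compound 4 `CCCc1cc(-c2ccc(F)cc2)n(Cc2ccc(C(=O)NO)cc2)n1`, differs from compound 2 in one place: ethyl in place of hydrogen on a saturated chain carbon bound to an aromatic carbon. Cut one bond further out, the same change reads methyl to propyl. Going by the values given here, none of the measured steps touches this position; the only step on record, from compound 2 to compound 3, concerns methyl in place of fluoro on an aromatic carbon, and that step stayed within the scatter. Among the compounds with values here, with no direct precedent, the expected step from compound 2 to compound 4 in this assay is no change at the digits printed from compound 2 to compound 4 (within the scatter), none beyond the scatter in either direction. Compound 4 is therefore estimated at 20 nM, with a range from 8 nM to 50 nM.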

Compound 4, half-maximal inhibitory concentration: 167 nM
Beside the measured number, compound 4's estimate is 8.4-fold (0.92 log units) below it; the measured number lies above the stated range.
By their numbers in this assay, from the lowest: compound 1; then compounds 2 and 3 (each within the scatter of the next); then compound 4.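

In this assay, the position carrying the methyl on the core of compound 2 proves sensitive to the group placed there: methyl to propyl gives an 8.4-fold higher number from compound 2 to compound 4 (0.92 log units; beyond the scatter), and of the two steps shown, this is the one that lies beyond the scatter. The other, methyl in place of fluoro on an aromatic carbon, gives a 1.5-fold higher number from compound 2 to compound 3 (0.16 log units; within the scatter) and stays within it, so a change on the saturated chain carbon bound to an aromatic carbon is what shifts the number here, towards weaker inhibition. Nothing available accounts for the size or direction of this step.

The compounds shown leave open whether an ethyl in place of the methyl would already give a step of this size, or whether a butyl or a longer chain would raise the number further. They also leave open how an amine or a carboxylic acid in place of the propyl would read in this assay, and whether the same methyl to propyl change in compound 1 would give a comparable step.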